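A few compounds are considered here, and "the series" means these few. Any claim that something is new, unique, unknown or untested is made for them only; others in the source may bear on it.

Working notes on the series. In a functional assay on Vero cells (Chlorocebus sabaeus) for inhibition (a lower number here means a stronger inhibitor, a higher number a weaker inhibitor), compound 1 `Clc1nc(-c2ccco2)c2ncn(Cc3ccc(Cl)c(Cl)c3)c2n1` gives > 10 ug/mL, which is a limit and not a number. Compound 2 `Clc1cccc(Cn2cnc3c(-c4ccco4)nc(Cl)nc32)c1` gives > 10 ug/mL, again a limit and not a number. The two compounds share one reading: the limit of > 10 ug/mL in this assay, at which 2 of the 2 values shown sit. Compound 2 therefore has no readable position in this assay.

Among the measured compounds shown here, the only measured step, a step that the two limits leave unreadable from compound 1 to compound 2, puts hydrogen in place of chloro on an aromatic carbon. Its size cannot be read, so it offers no scale for the next change.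

Compound 3 `COc1cccc(Cn2cnc3c(-c4ccco4)nc(Cl)nc32)c1` carries methoxy in place of chloro on an aromatic carbon, meta to a large group: methoxy in place of chloro on an aromatic carbon. For the measured compounds named here, no measured step covers this exchange directly. Since compound 2 stands at the limit > 10 ug/mL, no step beyond the scatter is expected, and no direction can be assigned. The expected step is a step that the limit leaves unreadable from compound 2 to compound 3. For compound 3 the estimated value is 14 ug/mL, with an expected range from 6 ug/mL to 30 ug/mL. A further limit reading in this assay is the likeliest outcome.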

Compound 3, half-maximal inhibitory concentration: > 10 ug/mL
Compound 3 ended at the assay's limit; the forecaster's own chance of this, stated with the estimate: 80%; the middle value is on the limit's open side.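

No new step can be read: compound 3, like compound 1 and compound 2, gives only a limit and not a number, so the steps among the three cannot be read: the limit of > 10 ug/mL in this assay, at which 3 of the 3 values shown sit.

The compounds shown leave open how strongly any of the three inhibits in this assay, and whether exchanging 3,4-dichlorophenyl, 3-chlorophenyl and 3-methoxyphenyl changes the reading at all.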